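Nitro for fluoro, repeated on a second core

The compounds below may be only part of what the source reports. "The series", "measured", "known", "first", "only" and "open" are said of these compounds alone.

Four compounds are in view. Compound 1 `O=C1C=C[C@@H](OCc2ccccc2)[C@@H]([C@@H](COC(=O)/C=C/c2ccc(F)cc2)OCc2ccccc2)O1` and compound 2 `O=C1C=C[C@@H](OCc2ccccc2)[C@@H]([C@@H](COC(=O)/C=C/c2ccc([N+](=O)[O-])cc2)OCc2ccccc2)O1` share one core; compound 3 `CC(=O)O[C@@H]1C=CC(=O)O[C@@H]1[C@@H](COC(=O)/C=C/c1ccc(F)cc1)OC(C)=O` and compound 4 `CC(=O)O[C@@H]1C=CC(=O)O[C@@H]1[C@@H](COC(=O)/C=C/c1ccc([N+](=O)[O-])cc1)OC(C)=O` share another. The difference between the two cores is not broken down here.

In a functional assay on MCF7 cells (Homo sapiens) for antiproliferative activity, read by MTT assay, with a stated time of 6 days (on this read-out higher numbers stand for weaker inhibition and lower numbers for stronger inhibition), compound 1 gives 3010 nM. Compound 2 differs from compound 1 by nitro in place of fluoro on an aromatic carbon and in this assay compound 2 gives 1660 nM; the step is a 1.8-fold lower number from compound 1 to compound 2 (0.26 log units; within the scatter). In this assay compound 3 gives 4260 nM, the highest of the three numbers; its gap to compound 1 is within the scatter, its gap to compound 2 beyond it.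

Compound 4 is compound 3 with the same change: nitro in place of fluoro on an aromatic carbon. The place of the change reads the same in both pairs, so the two changes are the same kind of change on different cores.

Among the measured compounds shown here, only one measured instance of the change exists, so the expectation for compound 4 rests on that single pair and on its own core. The step from compound 3 to compound 4 is expected to be a 1.8-fold lower number from compound 3 to compound 4 (0.25 log units; within the scatter), because a 1.8-fold lower number from compound 1 to compound 2 (0.26 log units; within the scatter) and nothing in the three measured numbers points to the second core answering the change differently. In this assay compound 4 is therefore expected to come in at 2400 nM, with an expected range from 1200 nM to 4800 nM.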

Compound 4, half-maximal inhibitory concentration: 1400 nM
Beside the measured number, compound 4's estimate is 1.7-fold (0.23 log units) above it, within the range that was stated.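

Notes on carrying the change between cores. In this assay, nitro in place of fluoro on the core of compound 3 gives a 3.0-fold lower number from compound 3 to compound 4 (0.48 log units; beyond the scatter), and the number falls on both cores, so the direction of the change carries over in these two pairs, with no difference in size that can be claimed: the same change on two cores in this assay, a 1.8-fold lower number (0.26 log units; within the scatter) from compound 1 to compound 2 and a 3.0-fold lower number (0.48 log units; beyond the scatter) from compound 3 to compound 4, 1.7-fold (0.22 log units) apart, within the scatter of two such steps. Taken alone, only the step on the core of compound 3 lies beyond the scatter, while a 1.8-fold lower number from compound 1 to compound 2 (0.26 log units; within the scatter) does not, so the pairs do not establish a clear effect of the change on the core of compound 1. Two pairs in a single cell assay show neither why the number falls nor whether the step would hold on any further core.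

Fluoro and nitro are the only groups compared at this place on the aromatic ring, so it remains open how a methoxy group, a nitrile or an amine in the same place would read in this assay. Also open, as far as these compounds go, is whether the step from 4-fluorophenyl to 4-nitrophenyl would persist if the ester linking this ring to the core were replaced by an amide.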